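The source may hold more compounds than are shown below. What is called first, only, known or untested is meant among the compounds shown, and "the series" means these compounds.

The study compares four compounds built on two closely related cores. Compound 1 `COC(=O)c1ccc(-c2cn(CCCC(=O)Nc3ccc(C)cc3)nn2)cc1` carries a methoxycarbonyl group, and compound 2 `Cc1ccc(NC(=O)CCCn2cc(-c3ccc(C(F)(F)F)cc3)nn2)cc1` is its counterpart bearing trifluoromethyl at the same spot. Compound 3 `COC(=O)c1ccc(-c2cn(CCCC(=S)Nc3ccc(C)cc3)nn2)cc1` keeps the methoxycarbonyl group of compound 1 but differs from it elsewhere; the difference between the two cores is not broken down here. Compound 4 `Cc1ccc(NC(=S)CCCn2cc(-c3ccc(C(F)(F)F)cc3)nn2)cc1` has not yet been tested.

In a functional assay on A549 cells (Homo sapiens) for inhibition, read by MTT assay, with a stated time of 72 h (a lower number here means a stronger inhibitor, a higher number a weaker inhibitor), compound 1 gives > 100000 nM, which is a limit of the assay rather than a measured number. Compound 2 gives 25000 nM in this assay. The change trifluoromethyl in place of methoxycarbonyl on an aromatic carbon therefore produces an at least 4.0-fold lower number from compound 1 to compound 2 (0.60 log units; beyond the scatter), and the size of that step is known only as a bound because of the limit of > 100000 nM in this assay, at which 1 of the 3 values shown sits. Compound 3 gives 50000 nM in this assay, a value that sits within the scatter of compound 2.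

Compound 4 differs from compound 3 by trifluoromethyl in place of methoxycarbonyl on an aromatic carbon, the same change that separates compound 1 from compound 2, made at an identical place. The author expects that this change will move compound 4 by a 4.2-fold lower number from compound 3 to compound 4 (0.62 log units; beyond the scatter) relative to compound 3. That expectation rests on the earlier step of an at least 4.0-fold lower number from compound 1 to compound 2 (0.60 log units; beyond the scatter), which the same change made once before, while allowing for the chance that a change on a different core does not repeat in full. For compound 4 the estimated value in this assay is 12000 nM, expected to fall between 3000 nM and 50000 nM.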

Compound 4, half-maximal inhibitory concentration: 5500 nM
Compound 4: the middle estimate sits 2.2-fold (0.34 log units) above what was measured; low and high end bracket the measured number.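

In this assay, trifluoromethyl in place of methoxycarbonyl on an aromatic carbon again gives a lower number on the second core, with a 9.1-fold lower number from compound 3 to compound 4 (0.96 log units; beyond the scatter), so in the two pairs shown the change carries over in direction, each step lying beyond the scatter. Whether it also carries over in size is a separate question, and the two steps compare as follows: the same change on two cores in this assay, an at least 4.0-fold lower number (0.60 log units; beyond the scatter) from compound 1 to compound 2 and a 9.1-fold lower number (0.96 log units; beyond the scatter) from compound 3 to compound 4; the limit leaves it open whether they differ. Compound 1 gives > 100000 nM, which is a limit and not a number; the earlier step is thus known only as a bound, and the two pairs show neither that the change does more on one core than on the other nor that it would repeat on any further core.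

The compounds shown leave open how other groups at the same place on the aromatic ring would read on either core, for example a nitrile, a carboxylic acid or an amine in place of trifluoromethyl or methoxycarbonyl. They also leave open whether a longer chain on either core would keep this step, and whether the same change would give a similar step in any other assay.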